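Aminophenyl to aminopyridyl on the shared core

The compounds below may be only part of what the source reports. "The series", "measured", "known", "first", "only" and "open" are said of these compounds alone.

Measured so far:
compound 1 `Nc1cc(NS(=O)(=O)c2ccccc2)cc(-c2cnc3[nH]cc(-c4ccncc4)c3c2)c1`: 8800 nM
compound 2 `Nc1cccc(-c2cnc3[nH]cc(-c4ccncc4)c3c2)c1`: 2300 nM

Going by the values given here, in a functional assay on MCF7 cells (Homo sapiens) for cytotoxicity, read by MTT assay, with a stated time of 48 h (a lower number here means a stronger inhibitor, a higher number a weaker inhibitor), compound 2 gives 2300 nM and holds the lowest of the two numbers; the only step, a 3.8-fold lower number from compound 1 to compound 2 (0.58 log units; beyond the scatter), removed a (phenylsulfonyl)amino group. Compound 3 `Nc1cncc(-c2cnc3[nH]cc(-c4ccncc4)c3c2)c1` instead carries 5-aminopyridin-3-yl in place of 3-aminophenyl on an aromatic carbon. Among the compounds with values here, no measured step changes this ring, so the step from compound 1 to compound 2 bears only loosely on it. Compound 3 is expected at 2500 nM, range 800 nM to 8000 nM, with an expected step of a 1.1-fold higher number from compound 2 to compound 3 (0.04 log units; within the scatter) that stays within the scatter.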

Compound 3, half-maximal inhibitory concentration: 5100 nM
Compound 3: the middle estimate sits 2.0-fold (0.31 log units) below what was measured; the measured number falls inside the stated range.
By their numbers in this assay, from the lowest: compound 2; then compounds 3 and 1 (each within the scatter of the next).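

In this assay, going by these compounds alone, this is the first change to the aromatic ring bearing the amine rather than to a substituent on it. Replacing 3-aminophenyl with 5-aminopyridin-3-yl gives a 2.2-fold higher number from compound 2 to compound 3 (0.35 log units; beyond the scatter), so this ring position responds to a change of ring atom even with the amine retained. Compound 2 keeps the lowest number of the series. Nothing measured on these compounds accounts for the step.

Still open, from the compounds shown here alone, is whether the amine itself matters, as a hydroxyl or methoxy group in its place would show. Also open, going by these compounds, is whether a fluorine on the 3-aminophenyl ring would move the number at all.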